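Replacing azetidine with an anilino group on the core

The source may hold more compounds than are shown below. What is called first, only, known or untested is meant among the compounds shown, and "the series" means these compounds.

Compound 1 `O=C1C(Nc2ccc(I)cc2)=CC(=O)c2c1nc1n2[C@H]2OC[C@@H](O)[C@H]2OC1` carries a (4-iodophenyl)amino group on the double-bonded ring carbon; in a functional assay on MCF7 cells (Homo sapiens) for inhibition, read by sulforhodamine B assay (a lower number here means a stronger inhibitor, a higher number a weaker inhibitor), compound 1 gives 3890 nM. Compound 2 `O=C1C(N2CCC2)=CC(=O)c2c1nc1n2[C@H]2OC[C@@H](O)[C@H]2OC1` carries azetidin-1-yl at that place. In this assay compound 2 gives only a limit of the assay, > 16000 nM, so on the numbers shown it stands at the open, weak end of the series. The measured step of an at least 4.1-fold higher number from compound 1 to compound 2 (0.61 log units; beyond the scatter) is bounded rather than fixed because compound 2 sits at the limit of > 16000 nM in this assay, at which 1 of the 2 values shown sits. Compound 3 `O=C1C(Nc2cccc(Cl)c2)=CC(=O)c2c1nc1n2[C@H]2OC[C@@H](O)[C@H]2OC1` differs from compound 2 by (3-chlorophenyl)amino in place of azetidin-1-yl on a double-bonded ring carbon. Among the measured compounds shown here, the one measured step runs the other way, from an arylamino to the azetidine, and was at least modest; restoring an arylamino in place of the azetidine is therefore expected to reverse it, a fall of about an at least 3.2-fold lower number from compound 2 to compound 3 (0.50 log units; beyond the scatter) in this assay. Compound 3 is thus estimated at 5000 nM, within 1500 nM to 16000 nM.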

Compound 3, half-maximal inhibitory concentration: 2970 nM
Beside the measured number, compound 3's estimate is 1.7-fold (0.23 log units) above it; low and high end bracket the measured number.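

In this assay, (3-chlorophenyl)amino in place of azetidin-1-yl gives an at least 5.3-fold lower number from compound 2 to compound 3 (0.73 log units; beyond the scatter), so the gap from the azetidine now holds for two arylamino groups, compound 1 and compound 3, rather than one. Within the arylamino pair, the change of aryl group gives a 1.3-fold lower number from compound 1 to compound 3 (0.12 log units; within the scatter), so 3-chlorophenyl and 4-iodophenyl on the amine nitrogen do not separate in this assay. The size of the gap from the azetidine stays a bound because compound 2 sits at a limit of the assay: the limit of > 16000 nM in this assay, at which 1 of the 3 values shown sits.

Still open, as far as these compounds go, is whether the gain belongs to the aromatic ring or to the amine hydrogen, which enter together here; a cyclohexylamino or a methyl(phenyl)amino group would pull the two apart. Also open, from the compounds shown here alone, is what an unsubstituted phenylamino group or a 4-methoxyphenylamino group would give at this place.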